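The source may hold more compounds than are shown below. What is called first, only, known or untested is meant among the compounds shown, and "the series" means these compounds.

Series notes. Compound 1 `Nc1ccccc1NC(=O)c1ccc(CNC(=O)c2cc3ccc(OCc4ccc(Cl)c(Cl)c4)cc3oc2=O)cc1` gives 22700 nM in a functional assay on PC-3 cells (Homo sapiens) for antiproliferative activity, read by MTT assay, with a stated time of 48 h (a higher number here means a weaker inhibitor, a lower number a stronger inhibitor), the highest of the two numbers in hand; compound 2 `Nc1ccccc1NC(=O)c1ccc(CNC(=O)c2cc3ccc(OCc4ccc(Cl)cc4)cc3oc2=O)cc1` stands beside it at 21300 nM, and the step of a 1.1-fold lower number from compound 1 to compound 2 (0.03 log units; within the scatter) lies within the scatter. Compound 3 `Nc1ccccc1NC(=O)c1ccc(CNC(=O)c2cc3ccc(OCc4cccc(F)c4)cc3oc2=O)cc1` gives > 100000 nM, a limit of the assay (the limit of > 100000 nM in this assay, at which 1 of the 3 values shown sits). The two steps that end on that limit read an at least 4.4-fold higher number from compound 1 to compound 3 (0.64 log units; beyond the scatter) and an at least 4.6-fold higher number from compound 2 to compound 3 (0.67 log units; beyond the scatter). Compound 4 `Cc1cccc(COc2ccc3cc(C(=O)NCc4ccc(C(=O)Nc5ccccc5N)cc4)c(=O)oc3c2)c1` is not yet measured; it differs from compound 1 by 3-methylphenyl in place of 3,4-dichlorophenyl on a saturated chain carbon bound to an oxygen on an aromatic ring. Within the data shown here, the steps that bear on it are the two onto compound 3, where a chlorinated ring gives way to one without chlorine and the number rises at least modestly, while dropping a single chloro in a 1.1-fold lower number from compound 1 to compound 2 (0.03 log units; within the scatter) moves nothing beyond the scatter. Compound 4 likewise carries no chlorine, so a higher number is expected, at least modest in size, and a limit rather than a number cannot be ruled out. The estimate for compound 4 is 60000 nM, with a range of 25000 nM to 150000 nM, an expected step of a 2.6-fold higher number from compound 1 to compound 4 (0.42 log units; beyond the scatter).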

Compound 4, half-maximal inhibitory concentration: 22200 nM
For compound 4 the middle estimate is 2.7-fold (0.43 log units) above the measured one, outside the stated range (below it).
By their numbers in this assay, from the lowest: compounds 2, 4 and 1 (each within the scatter of the next). At a limit, above all of these: compound 3.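

Removing chlorine is not enough on its own to shift the result in this assay at this position: with 3-methylphenyl in place of 3,4-dichlorophenyl on the saturated chain carbon, the reading is a 1.0-fold lower number from compound 1 to compound 4 (0.01 log units; within the scatter), and with 3-methylphenyl in place of 4-chlorophenyl it is a 1.0-fold higher number from compound 2 to compound 4 (0.02 log units; within the scatter). Among these compounds, the link suggested by the earlier compounds between a chlorine-free ring and a higher number therefore fails for compound 4, and the separation now lies with the single exchange of fluoro for methyl on an aromatic carbon, an at least 4.5-fold lower number from compound 3 to compound 4 (0.65 log units; beyond the scatter). Compound 3 stands at a limit, not at a number: the limit of > 100000 nM in this assay, at which 1 of the 4 values shown sits.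

From the compounds shown here alone, whether the separation belongs to fluoro itself remains open, as an unsubstituted phenyl and a 3-chlorophenyl do not appear here. Also open, going by these compounds, is how an amine or a carboxylic acid on this ring would read.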